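Aryl urea series: cytotoxicity on CRL2813 cells

The source may report more compounds than this note shows. Statements on the series, on what has been measured and on what is new or still open speak of the compounds shown alone.

Measured so far:
compound 1, `O=C(Nc1cccc(C(F)(F)F)c1)N[C@H]1CC[C@H](Oc2cccc(C(F)(F)F)c2)CC1`: 1300 nM
compound 2, `O=C(Nc1ccc([N+](=O)[O-])cc1)N[C@H]1CC[C@H](Oc2ccc(F)cc2)CC1`: 2300 nM
compound 3, `COC(=O)c1cccc(NC(=O)N[C@H]2CC[C@H](Oc3ccc(F)cc3)CC2)c1`: 9200 nM

In a functional assay on CRL2813 cells (Homo sapiens) for cytotoxicity, read by sulforhodamine B assay, with a stated time of 5 days (a lower number here means a stronger inhibitor, a higher number a weaker inhibitor), compound 2 stands second highest of the three numbers. Its nearest neighbour is compound 1, which gives 1300 nM; that gap is within the scatter, so no order between the two is claimed. Compound 3 gives 9200 nM, a gap from compound 2 that lies beyond the scatter.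

Compound 4, `O=C(Nc1ccccc1I)N[C@H]1CC[C@H](Oc2ccc(F)cc2)CC1`, is not yet measured. It differs from compound 2 as follows: 2-iodophenyl in place of 4-nitrophenyl on an amide-type nitrogen. For the measured compounds named here, no step between measured compounds matches this change, so the expectation rests on the number for compound 2 alone. No step beyond the scatter is expected; the estimated step of a 1.3-fold higher number from compound 2 to compound 4 (0.12 log units; within the scatter) is small, towards a slightly higher number. Compound 4 is expected to give 3000 nM in this assay, in the range 1000 nM to 9000 nM.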

Compound 4, half-maximal inhibitory concentration: > 20000 nM
Compound 4 gave a limit, no number (the forecaster's own chance of this, stated with the estimate: 5%); at least 6.6-fold (0.82 log units) between middle value and limit.
By their numbers in this assay, from the lowest: compounds 1 and 2 (each within the scatter of the next); then compound 3. At a limit, above all of these: compound 4.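

In this assay compound 4 gives > 20000 nM, a limit of the assay and not a number. For the compounds shown here, the change of 4-nitrophenyl to 2-iodophenyl on the amide-type nitrogen gives an at least 8.6-fold higher number from compound 2 to compound 4 (0.93 log units; beyond the scatter), the first one-place step, and it shows that the aryl group at this position is not interchangeable. The size of this step is only a lower bound: the limit of > 20000 nM in this assay, at which 1 of the 4 values shown sits.

The compounds shown leave open whether the iodine or the loss of the nitro group drives this step. On these data alone, how a phenyl ring carrying chlorine or an amine would read at this nitrogen also remains open.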